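Adding Isopropyl to an Aromatic Ring: Expected Effect

A few compounds are considered here, and "the series" means these few. Any claim that something is new, unique, unknown or untested is made for them only; others in the source may bear on it.

Compound 2 `O=C(/C=C/c1ccc(/C=C/C(=O)c2ccccc2)o1)NO` was tested in an assay on isolated protein for inhibition of histone deacetylase 4 (Homo sapiens), read by fluorescence (on this read-out higher numbers stand for weaker inhibition and lower numbers for stronger inhibition), and gives 22800 nM, the second highest of the three numbers recorded. The nearest is compound 1 `O=C(/C=C/c1ccc(/C=C/C(=O)c2cccc(Cl)c2)o1)NO`, which in this assay gives 12900 nM. The furthest is compound 3 `O=C(NO)c1ccc(/C=C/c2ccccc2O)o1`, which in this assay gives 74200 nM. For the measured compounds named here, the only measured single change is a 1.8-fold higher number from compound 1 to compound 2 (0.25 log units; within the scatter), a swap on the same six-membered aromatic ring of carbon only that carries the change of interest here. Compound 4 `CC(C)c1ccc(C(=O)/C=C/c2ccc(/C=C/C(=O)NO)o2)cc1` differs from compound 2 by isopropyl in place of hydrogen on an aromatic carbon. Since the measured swap between chloro and hydrogen on that ring stayed within the scatter, and nothing measured bears directly on an isopropyl at this place, a small step in either direction is expected. The estimate for compound 4 in this assay is 18000 nM, with a range from 8000 nM to 40000 nM. This estimate means a 1.3-fold lower number from compound 2 to compound 4 (0.10 log units; within the scatter), a step expected to stay within the scatter.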

Compound 4, half-maximal inhibitory concentration: 4890 nM
Estimate against measurement, compound 4: 3.7-fold (0.57 log units) above, outside the stated range (below it).
By their numbers in this assay, from the lowest: compound 4; then compounds 1 and 2 (each within the scatter of the next); then compound 3.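

Adding an isopropyl to this ring, para to a large group, gives a real gain in this assay: the step is a 4.7-fold lower number from compound 2 to compound 4 (0.67 log units; beyond the scatter), so a hydrogen at this place can be replaced with a clear lowering of the number. The earlier swap between chloro and hydrogen on this ring, a 1.8-fold higher number from compound 1 to compound 2 (0.25 log units; within the scatter), stayed too small to show whether changes on this ring matter at all, whereas this step shows that at least one does. Nothing available explains why isopropyl has this effect.

Going by these compounds, whether a methyl, a tert-butyl or an amine at the same place would also lower the number remains open. On these data alone, it is also open whether an isopropyl would produce a similar step on the core of compound 3.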